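The compounds below may be only part of what the source reports. "The series", "measured", "known", "first", "only" and "open" are said of these compounds alone.

In a functional assay on cells (Cancer cell lines, Homo sapiens) for inhibition (on this read-out lower numbers stand for stronger inhibition of growth and higher numbers for weaker inhibition of growth), compound 1 (`Cc1cn2c(/C=N/Nc3ccccn3)c(-c3ccc(Cl)c([N+](=O)[O-])c3)nc2s1`) gives 15500 nM, compound 2 (`Cc1cn2c(/C=N/NC(=N)N)c(-c3ccsc3)nc2s1`) gives 10200 nM and compound 3 (`N=C(N)N/N=C/c1c(-c2ccsc2)nc2sccn12`) gives 14800 nM. Compound 3 thus sits within the scatter of both other compounds. Compound 4 (`Cc1cc(-c2nc3sccn3c2/C=N/NC(=N)N)c(C)s1`) has 2,5-dimethylthiophen-3-yl in place of thiophen-3-yl on an aromatic carbon. Going by the values given here, the one measured step involving a methyl group, a 1.5-fold higher number from compound 2 to compound 3 (0.16 log units; within the scatter), lies on the shared core and not on the thiophen-3-yl group, and it stays within the scatter. It is only weak guidance, so no step beyond the scatter is expected in this assay. The expected step is a 1.2-fold lower number from compound 3 to compound 4 (0.09 log units; within the scatter). For compound 4 the estimated value is 12000 nM, with an expected range of 5000 nM to 28000 nM.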

Compound 4, concentration for 50% growth inhibition: 17800 nM
Estimate against measurement, compound 4: 1.5-fold (0.17 log units) below; the measured number falls inside the stated range.
By their numbers in this assay, from the lowest: compounds 2, 3, 1 and 4 (each within the scatter of the next).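

In this assay 2,5-dimethylthiophen-3-yl in place of thiophen-3-yl gives a 1.2-fold higher number from compound 3 to compound 4 (0.08 log units; within the scatter) and thus no step beyond the scatter at this position. The earlier step concerned a methyl group on the shared core, whereas this one shows that adding two methyl groups to the thiophene ring leaves the read-out within the scatter. No measurement at hand offers an explanation for this result.

Still open, from the compounds shown here alone, is whether an amine or a carboxylic acid on the thiophene ring, or a longer alkyl chain there, would move the number beyond the scatter.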